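Unmasking a Hydroxyl on a Shared Core

A few compounds are considered here, and "the series" means these few. Any claim that something is new, unique, unknown or untested is made for them only; others in the source may bear on it.

The study measures cytotoxicity in a functional assay on MKN-45 cells (Homo sapiens) for cytotoxicity, read by Western blot, with a stated time of 1 h; on this read-out lower numbers stand for stronger inhibition and higher numbers for weaker inhibition. Compound 1 `Cn1cc(-c2ccc3cnn(Cc4ccc5ncccc5c4)c3c2)cn1` gives 12900 nM in this assay. Compound 2 `CC(C)(C)[Si](C)(C)O[C@H]1CC[C@H](n2cc(-c3ccc4cnn(Cc5ccc6ncccc6c5)c4c3)cn2)CC1` gives 11000 nM in this assay, and on the two numbers available compound 2 sits alongside compound 1, the gap between them falling within the usual scatter of repeated measurements, so neither can be called the more potent.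

Compound 3 `O[C@H]1CC[C@H](n2cc(-c3ccc4cnn(Cc5ccc6ncccc6c5)c4c3)cn2)CC1` follows from compound 2 by a single change: a hydrogen atom in place of a group of 7 heavy atoms (6 carbon, 1 silicon; no ring), on an oxygen on a saturated carbon. In words, a hydrogen atom takes the place of a group of 7 heavy atoms (6 carbon, 1 silicon; no ring), on an oxygen on a saturated carbon whose other neighbours are a saturated ring carbon. Going by the values given here, no step between measured compounds offers a precedent for such a change, so the expectation rests on the two values alone, both lying in the same weak region.

In this assay compound 3 is expected to give about 8000 nM, with a likely range from 3000 nM to 25000 nM. The step of a 1.4-fold lower number from compound 2 to compound 3 (0.14 log units; within the scatter) is therefore estimated to be small, probably not beyond the scatter, with at most a slight lean toward stronger inhibition.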

Compound 3, half-maximal inhibitory concentration: 5450 nM
Beside the measured number, compound 3's estimate is 1.5-fold (0.17 log units) above it; measured number inside the range.
By their numbers in this assay, from the lowest: compounds 3, 2 and 1 (each within the scatter of the next, the first and the last beyond it).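

In this assay, a hydrogen atom in place of the group of 7 heavy atoms on the oxygen gives a 2.0-fold lower number from compound 2 to compound 3 (0.30 log units; within the scatter), so at this position the free hydroxyl and its silicon-bearing form cannot be told apart on this read-out. Going by these compounds alone, the wider change on the aromatic nitrogen, 4-hydroxycyclohexyl in place of methyl, gives a 2.4-fold lower number from compound 1 to compound 3 (0.37 log units; beyond the scatter); this is the first step to pass the scatter, though only modestly, and compound 3 still stands at a high number (5450 nM). Nothing available explains why either step has the size it has.

The compounds shown leave open whether the modest gain needs the hydroxyl at all, since the cyclohexyl ring without any group on it, or with an amine or a carboxylic acid in place of the hydroxyl, would separate the contribution of the ring from that of the group it carries. They also leave open whether a methyl ether on the same oxygen, or a longer chain on the aromatic nitrogen, would move the number further in this assay.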